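Swapping Thiophene for Furan on a Weakly Cytotoxic Compound

This account rests on a few compounds, and the source may have more. Where it says the series, first, only, none or still open, it means among the compounds named here.

Measured in a functional assay on KB 3-1 cells (Homo sapiens) for cytotoxicity, read by MTT assay, with a stated time of 68 h; on this read-out lower numbers stand for stronger inhibition and higher numbers for weaker inhibition:
- Compound 1 `O=C(Nc1cccc(-c2ccsc2)c1)C(Cl)Cl`: > 50000 nM
- Compound 2 `O=C(Nc1cccc(-c2ccccc2F)c1)C(Cl)Cl`: 48300 nM
- Compound 3 `CC(C)c1ccc(-c2cc(NC(=O)C(Cl)Cl)cc(-c3ccc(C(C)C)cc3)c2)cc1`: > 30000 nM

Compound 1 is recorded at > 50000 nM, which is a limit of the assay and not a number. Compound 3 is recorded at > 30000 nM, and this too is only a limit. Among the compounds with values here, compound 2 gives 48300 nM, the only true number among the three. No two of these measured compounds differ in just one place, so the data offer no direct guide to the size of a single structural change.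

The next compound to test is compound 4 `O=C(Nc1cccc(-c2ccoc2)c1)C(Cl)Cl`. It has furan-3-yl in place of thiophen-3-yl on an aromatic carbon. The rest of the core of compound 1 stays the same.

With compound 1 at > 50000 nM, the starting point is a limit, and a small swap is expected to leave the result in the same region. The expected result is a number no higher from compound 1 to compound 4 (the limit leaves the size open), which means no step beyond the usual scatter of this assay. The assay may well report only a limit again. For compound 4 the estimated value is 50000 nM, with an expected range from 25000 nM to 100000 nM.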

Compound 4, half-maximal inhibitory concentration: > 50000 nM
Compound 4: no number, only a limit (the forecaster's own chance of this, stated with the estimate: 60%); the middle value sits exactly at the limit.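

In this assay, compound 1 and compound 4 both stop at a limit of the assay and not at a number, and the step between them cannot be read. The compounds shown leave open how strongly either compound acts on these cells, and whether furan-3-yl in place of thiophen-3-yl changes that at all.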